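The source may hold more compounds than are shown below. What is called first, only, known or untested is meant among the compounds shown, and "the series" means these compounds.

Measured so far in an ADME assay for permeability, using PAMPA, with a stated time of 30 min, at pH 7.4; a higher number here means that the compound crosses the layer faster, a lower number that the compound crosses the layer more slowly:
compound 1 `COc1ccc(F)cc1CNCCCNc1ccnc2cc(CCc3ccccc3)ccc12`: 23 10^-6 cm/s
compound 2 `COc1ccc(F)cc1CNCCCNc1ccnc2cc(Oc3ccc(Cl)cc3)ccc12`: 317 10^-6 cm/s
compound 3 `COc1ccc(F)cc1CNCCCNc1ccnc2cc(-c3ccc(C(F)(F)F)cc3)ccc12`: 237 10^-6 cm/s

Compound 3 stands second highest of the three numbers. Its nearest neighbour is compound 2, with a 1.3-fold lower number from compound 2 to compound 3 (0.13 log units; within the scatter), a gap within the scatter; the furthest is compound 1, with a 10-fold higher number from compound 1 to compound 3 (1.01 log units; beyond the scatter), a large step.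

Compound 4 `COc1ccc(F)cc1CNCCCNc1ccnc2cc(Oc3ccccc3)ccc12` has not yet been run in this assay. Against compound 3 the change is phenoxy in place of 4-(trifluoromethyl)phenyl on an aromatic carbon.

For the measured compounds named here, two measured steps bear on this. a 14-fold higher number from compound 1 to compound 2 (1.14 log units; beyond the scatter) and a 10-fold higher number from compound 1 to compound 3 (1.01 log units; beyond the scatter) both show a large rise on going from the phenethyl of compound 1 to either the 4-chlorophenoxy of compound 2 or the 4-(trifluoromethyl)phenyl of compound 3, whereas a 1.3-fold lower number from compound 2 to compound 3 (0.13 log units; within the scatter) shows the 4-chlorophenoxy and 4-(trifluoromethyl)phenyl compounds within the scatter of each other. Compound 4 carries a phenoxy group, the closer relative of the 4-chlorophenoxy of compound 2, so the step of a 1.1-fold lower number from compound 3 to compound 4 (0.03 log units; within the scatter) is expected to stay within the scatter, with no clear direction. Compound 4 is therefore estimated at 220 10^-6 cm/s, in the range 100 10^-6 cm/s to 450 10^-6 cm/s.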

Compound 4, apparent permeability: 317 10^-6 cm/s
The estimate for compound 4 lay 1.4-fold (0.16 log units) below the measured number; low and high end bracket the measured number.
By their numbers in this assay, from the lowest: compound 1; then compounds 3, 2 and 4 (each within the scatter of the next).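

In this assay, loss of the chloro from the 4-chlorophenoxy group gives no change at the digits printed from compound 2 to compound 4 (within the scatter), so the chloro is not required for the high number at this aromatic carbon. Plain phenoxy also stays level with 4-(trifluoromethyl)phenyl, with a 1.3-fold higher number from compound 3 to compound 4 (0.13 log units; within the scatter), and keeps the large separation from phenethyl, with a 14-fold higher number from compound 1 to compound 4 (1.14 log units; beyond the scatter), leaving compound 1 as the only one of the four apart from the others. No measurement at hand explains this separation.

Open, going by these compounds, is whether the low number of compound 1 goes with the saturated chain of phenethyl or with some other feature of that group; an unsubstituted phenyl or a benzyloxy group at this carbon would help to separate these. Also open, on these data alone, is how a carboxylic acid or an amine on the terminal ring would read here.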